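From Fluoro to Acetamido: Compound 1 and Compound 4

The compounds below may be only part of what the source reports. "The series", "measured", "known", "first", "only" and "open" are said of these compounds alone.

In an ADME assay on L02 cells (Homo sapiens) for cytotoxicity, read by MTT assay, with a stated time of 24 h (on this read-out higher numbers stand for weaker inhibition and lower numbers for stronger inhibition), compound 1 `COc1cc(/C=C2\CN(S(=O)(=O)c3ccc(F)cc3)C/C(=C\c3cc(OC)c(OC)c(OC)c3)C2=O)cc(OC)c1OC` gives 12100 nM. Compound 2 `COc1cc(/C=C2\CN(S(=O)(=O)c3ccc(F)cc3)C/C(=C\c3cc(OC)cc(OC)c3)C2=O)cc(OC)c1` gives 19800 nM, and compound 3 `CC(=O)Nc1ccc(S(=O)(=O)N2C/C(=C\c3ccccc3F)C(=O)/C(=C/c3ccccc3F)C2)cc1` gives 11600 nM. Compound 1 therefore sits among two close neighbours, and all three values lie within the usual scatter of one another.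

The next compound to be tested is compound 4 `COc1cc(/C=C2\CN(S(=O)(=O)c3ccc(NC(C)=O)cc3)C/C(=C\c3cc(OC)c(OC)c(OC)c3)C2=O)cc(OC)c1OC`. It keeps the core of compound 1 but has acetamido in place of fluoro on an aromatic carbon, para to a large group: acetamido in place of fluoro on an aromatic carbon.

For the measured compounds named here, no two measured compounds differ in only one place, so no direct measurement shows what this swap does. The nearest clue is compound 3, which also carries an acetamido group and gives 11600 nM. In this assay, the expected result is therefore no change beyond the scatter. The estimated step is a 1.1-fold higher number from compound 1 to compound 4 (0.03 log units; within the scatter). For compound 4, the estimated value is 13000 nM, with an expected range from 6500 nM to 26000 nM.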

Compound 4, half-maximal inhibitory concentration: 13600 nM
Compound 4: middle estimate off by 1.0-fold (0.02 log units), on the low side; measured number inside the range.
By their numbers in this assay, from the lowest: compounds 3, 1, 4 and 2 (each within the scatter of the next).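

In this assay, for the compounds shown here, this is the first direct reading at this position, since compound 1 and compound 4 differ in one place only: the step is a 1.1-fold higher number from compound 1 to compound 4 (0.05 log units; within the scatter). On the core of compound 1, then, the 4-fluorophenyl and 4-acetamidophenyl forms cannot be told apart on this read-out, even though the entering group brings 4 heavy atoms for 1 and adds a hydrogen-bond donor and a hydrogen-bond acceptor. No measurement shown here offers an explanation for this result.

This is a single swap on a single core, so it cannot show whether the same holds with the other groups on the two benzylidene arms. It also leaves open whether a free amine, a carboxylic acid or a longer alkyl chain at this position would stay within the scatter.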